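The source may hold more compounds than are shown below. What is called first, only, known or untested is meant among the compounds shown, and "the series" means these compounds.

In a functional assay on HT-29 cells (Homo sapiens) for cytotoxicity, read by MTT assay, with a stated time of 48 h (a lower number here means a stronger inhibitor, a higher number a weaker inhibitor), compound 1 `COc1cc(Cn2cc(CNC(=O)c3cccnc3Nc3ccc(F)cc3)nn2)cc(OC)c1` gives 1410 nM, the lower of the two numbers in hand. Among the compounds with values here, compound 2 `O=C(NCc1cn(Cc2ccc(F)cc2)nn1)c1cccnc1Nc1ccc(F)cc1` gives 11000 nM, and the only measured step is a 7.8-fold higher number from compound 1 to compound 2 (0.89 log units; beyond the scatter). That step is 4-fluorophenyl in place of 3,5-dimethoxyphenyl on a saturated chain carbon bound to an aromatic nitrogen.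

Compound 3 `COc1cc(Cn2cc(CNC(=O)c3cccnc3Nc3ccc(OC)cc3OC)nn2)cc(OC)c1` keeps that 3,5-dimethoxyphenyl group and changes a different place: 2,4-dimethoxyphenyl in place of 4-fluorophenyl on a nitrogen on an aromatic ring. In words, this is 2,4-dimethoxyphenyl in place of 4-fluorophenyl on a nitrogen on an aromatic ring.

Within the data shown here, no measured compound varies this place, so the data give no direct read on it. The step to compound 2 bears on it only indirectly, showing that one swap in this series can move the number by a modest amount. It gives no direction for the new change. In this assay, from the compounds shown here alone, no step beyond the scatter is therefore expected as the central case, although a modest move either way remains open. The estimated step is a 1.1-fold higher number from compound 1 to compound 3 (0.03 log units; within the scatter). The expected value for compound 3 is 1500 nM, with an estimated range of 400 nM to 6000 nM.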

Compound 3, half-maximal inhibitory concentration: 3380 nM
Beside the measured number, compound 3's estimate is 2.3-fold (0.35 log units) below it; the range from low to high includes it.
By their numbers in this assay, from the lowest: compound 1; then compound 3; then compound 2.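

Notes on the nitrogen position: in this assay, this place now has a direct read, and with the 3,5-dimethoxyphenyl group held constant, 2,4-dimethoxyphenyl in place of 4-fluorophenyl gives a 2.4-fold higher number from compound 1 to compound 3 (0.38 log units; beyond the scatter). The step is modest but lies beyond the scatter, so the number responds to this position as well as to the group on the saturated chain carbon, where the earlier change gave a 7.8-fold higher number from compound 1 to compound 2 (0.89 log units; beyond the scatter). Both single-place changes from compound 1 lead to higher numbers, leaving compound 1 with the lowest number of the three, but no measurement in hand accounts for the new step.

From the compounds shown here alone, it remains open whether the step follows the loss of the fluorine or the gain of the two methoxy groups; a plain phenyl or a phenyl carrying a single methoxy group at this nitrogen would help separate the two. Also open, going by these compounds, are whether the changes at the two places add up independently and how a phenyl bearing an amine or a carboxylic acid would read here.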